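The compounds below may be only part of what the source reports. "The series", "measured", "known", "first", "only" and "open" are said of these compounds alone.

Measured compounds, all in an assay on CHO cells for displacement of a labelled ligand from adenosine receptor A3 (Homo sapiens), read by scintillation counting, with a stated time of 120 min, tested at 1 uM; a higher number here means more inhibition at the concentration tested (going by the name of the read-out), a lower number less inhibition:

- compound 1 `N#Cc1c(N)nc(SCc2cccc(C(N)=O)c2)c(C#N)c1-c1ccc(OCC2CC2)cc1`, giving 1%
- compound 2 `N#Cc1c(N)nc(SCc2nc3ccccc3[nH]2)c(C#N)c1-c1ccc(OCC2CC2)cc1`, giving 1%
- compound 3 `N#Cc1c(N)nc(SCn2cncn2)c(C#N)c1-c1ccc(OCC2CC2)cc1`, giving 1%

The three compounds share one core and differ only in the group on the saturated chain carbon bound to the sulfur. Compound 3 stands level with compounds 1 and 2 at the digits shown; its nearest neighbour on the numbers is compound 1 and its furthest is compound 2, and neither gap exceeds the scatter. The steps between the measured compounds are no change at the digits printed from compound 1 to compound 2 (within the scatter), no change at the digits printed from compound 1 to compound 3 (within the scatter) and no change at the digits printed from compound 2 to compound 3 (within the scatter): three exchanges of the group at this position, none moving the read-out beyond the scatter.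

Compound 4 `N#Cc1c(N)nc(SCC(=O)NO)c(C#N)c1-c1ccc(OCC2CC2)cc1` is the next member. The change from compound 3 is hydroxycarbamoyl in place of 1H-1,2,4-triazol-1-yl on a saturated chain carbon bound to a sulfur. All three measured steps bear on it, since each swaps the group at the same place, and all were flat. The expectation for compound 4 is therefore no step beyond the scatter, a number 1 percentage points higher from compound 3 to compound 4 (within the scatter), with the read-out staying near the floor. Compound 4 is estimated at 2%, in the range 0% to 15%.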

Compound 4, a percentage reported as inhibition, at one concentration (the size of the read-out at that concentration, not a potency): 31%
Compound 4: the middle estimate sits 29 percentage points below what was measured; the whole stated range lies below it.
By their numbers in this assay, from the lowest: compounds 1, 2 and 3 (each within the scatter of the next); then compound 4.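

In this assay, this position proves able to move the read-out after all, with a number 30 percentage points higher from compound 3 to compound 4 (beyond the scatter), a number 30 percentage points higher from compound 2 to compound 4 (beyond the scatter) and a number 30 percentage points higher from compound 1 to compound 4 (beyond the scatter). Of the four groups on the saturated chain carbon bound to a sulfur, hydroxycarbamoyl alone has no ring, but a single compound cannot separate that feature from the other differences between these groups. Nothing available here accounts for the rise.

Open, from the compounds shown here alone, is whether the gain depends on the hydroxyl on the amide nitrogen or is retained without it, a question that a plain carbamoyl or a carboxylic acid on the same chain carbon would address. A read-out at one concentration also leaves the potency of compound 4 open.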